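Swapping isopropoxy for acetamido on a quinolone ester

A few compounds are considered here, and "the series" means these few. Any claim that something is new, unique, unknown or untested is made for them only; others in the source may bear on it.

Compound 2 `CCOC(=O)c1c(-c2cccc(OC(C)C)c2)[nH]c2cc(OC)ccc2c1=O` carries an isopropoxy group on its pendant aromatic ring. In an ADME assay on HEK293 cells (Homo sapiens) for cytotoxicity, read by luminescence, with a stated time of 72 h (a higher number here means that more compound is needed for the effect, a lower number that less compound is needed), compound 2 gives only a limit, > 22000 nM, so no number is known for it. Its close relative compound 1 `CCCOc1cccc(-c2[nH]c3cc(OC)ccc3c(=O)c2C(=O)OCC)c1` carries a propoxy group in the same place. In this assay compound 1 also gives only a limit, > 22000 nM. The step that the two limits leave unreadable from compound 1 to compound 2 therefore cannot be read, because both compounds sit at the limit of > 22000 nM in this assay, at which 2 of the 2 values shown sit.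

Compound 3 `CCOC(=O)c1c(-c2cccc(NC(C)=O)c2)[nH]c2cc(OC)ccc2c1=O` brings the next change: acetamido in place of isopropoxy on an aromatic carbon. Among the compounds with values here, no measured step bears on this change directly; the single step on record is unreadable, and both values gathered so far are limits. The expected size of the step in this assay can thus only be guessed as none beyond the scatter, with compound 3 most likely staying at the limit. Compound 3 is expected to give about 35000 nM in this assay, within a range from 12000 nM to 100000 nM. The step that the limit leaves unreadable from compound 2 to compound 3 that this estimate means is expected to be small.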

Compound 3, half-maximal effective concentration: > 22000 nM
Compound 3 was reported as a limit; the forecaster's own chance of this, stated with the estimate: 80%; the middle value lies beyond the limit too.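

The steps from compound 1 and from compound 2 to compound 3 cannot be read, because all three compounds give only a limit: the limit of > 22000 nM in this assay, at which 3 of the 3 values shown sit.

The compounds shown leave open whether propoxy, isopropoxy and acetamido differ at all in the concentration needed in this assay.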